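A few compounds are considered here, and "the series" means these few. Any claim that something is new, unique, unknown or untested is made for them only; others in the source may bear on it.

Measured so far:
compound 1 `CCCCCCc1cc2cn(Cc3cn(Cc4ccccc4)nn3)c(=O)nc2o1` — 67000 nM
compound 2 `O=c1nc2oc(CCCCl)cc2cn1Cc1cn(Cc2ccccc2)nn1` — 23500 nM

Both numbers come from a functional assay on CFPAC-1 cells (Homo sapiens) for antiproliferative activity, read by MTT assay, with a stated time of 72 h; on this read-out lower numbers stand for stronger inhibition and higher numbers for weaker inhibition. Among the measured compounds shown here, compound 2 holds the lower of the two values, and the step of a 2.9-fold lower number from compound 1 to compound 2 (0.46 log units; beyond the scatter) is the only measured change in the set. Compound 3 `O=c1nc2oc(C3CC3)cc2cn1Cc1cn(Cc2ccccc2)nn1` differs from compound 2 by cyclopropyl in place of 3-chloropropyl on an aromatic carbon. For the measured compounds named here, no measured step exchanges a 3-chloropropyl group for a ring, so the earlier step bears only loosely on this one. Only a small step in this assay is expected, in either direction, a 1.3-fold higher number from compound 2 to compound 3 (0.11 log units; within the scatter). Compound 3 is accordingly estimated at about 30000 nM, within 10000 nM to 90000 nM.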

Compound 3, half-maximal inhibitory concentration: 48500 nM
For compound 3 the middle estimate is 1.6-fold (0.21 log units) below the measured one; measured number inside the range.
By their numbers in this assay, from the lowest: compound 2; then compounds 3 and 1 (each within the scatter of the next).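

In this assay, a small ring on the aromatic carbon next to the ring oxygen gives a number in the same range as the open chains. With a 2.1-fold higher number from compound 2 to compound 3 (0.31 log units; beyond the scatter), 3-chloropropyl keeps a modest edge over cyclopropyl, while a 1.4-fold lower number from compound 1 to compound 3 (0.14 log units; within the scatter) leaves cyclopropyl and hexyl inseparable. No measurement shown accounts for these differences.

The compounds shown leave open whether the chlorine or the chain itself carries the lower number of compound 2. From the compounds shown here alone, how an amine, a carboxylic acid or a cyclohexyl ring would read at this position also stays open.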